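The source may report more compounds than this note shows. Statements on the series, on what has been measured and on what is new or still open speak of the compounds shown alone.

Measured so far:
compound 1, `CC(O)(CS(=O)(=O)c1ccc(F)cc1)c1cn(-c2ccc([N+](=O)[O-])c(C(F)(F)F)c2)nn1`: 36000 nM
compound 2, `CCOC(=O)c1ccc(-n2cc(C(C)(O)CS(=O)(=O)c3ccc(F)cc3)nn2)cc1`: > 300000 nM, a limit

In a functional assay on LNCaP cells (Homo sapiens) for inhibition (a higher number here means a weaker inhibitor, a lower number a stronger inhibitor), compound 1 gives 36000 nM, the only number among the two results shown. Compound 2 reaches a limit of this assay, > 300000 nM, and (the limit of > 300000 nM in this assay, at which 1 of the 2 values shown sits). Compound 3, `CC(O)(CS(=O)(=O)c1ccccc1)c1cn(-c2ccc([N+](=O)[O-])c(C(F)(F)F)c2)nn1`, differs from compound 1 in one place: hydrogen in place of fluoro on an aromatic carbon. Among the measured compounds shown here, no step between two measured compounds speaks to this change, so the step of a 1.3-fold higher number from compound 1 to compound 3 (0.10 log units; within the scatter) is expected to stay within the usual scatter. Compound 3 is therefore estimated at 45000 nM, with a range from 15000 nM to 130000 nM.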

Compound 3, half-maximal inhibitory concentration: 34000 nM
Compound 3: the middle estimate sits 1.3-fold (0.12 log units) above what was measured, and the stated range covers the measured number.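

In this assay, hydrogen in place of fluoro on the aromatic carbon gives a 1.1-fold lower number from compound 1 to compound 3 (0.02 log units; within the scatter). Among the compounds shown here, this is the first reading at this position, and it shows that on the core of compound 1, going from 4-fluorophenyl to phenyl leaves the inhibition in this assay within the scatter. Nothing shown offers a reason for this result.

Only fluoro and hydrogen are compared at this position. On these data alone, how a methoxy group, an amine or a carboxylic acid would behave there remains open.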